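Working notes: from compound 3 to compound 4

The source may hold more compounds than are shown below. What is called first, only, known or untested is meant among the compounds shown, and "the series" means these compounds.

Measured compounds and values in a functional assay on HEK293 cells for agonist activity at Free fatty acid receptor 1 (Homo sapiens), read by fluorescence and calcium flux, with a stated time of 10 min; a higher number here means a larger maximal response, a lower number a smaller maximal response:
compound 1, `O=C(O)CCc1ccc(OCC2COc3ccc(Br)cc3O2)cc1F`, gives 81%
compound 2, `CCOC(CC(=O)O)c1ccc(OCC2COc3ccc(Cl)cc3O2)cc1`, gives 46%
compound 3, `Cn1ccnc1C(CC(=O)O)c1ccc(OCC2COc3ccc(Cl)cc3O2)cc1`, gives 68%

Compound 3 stands second of the three in this assay: compound 1 lies above it by a gap beyond the scatter, and compound 2 lies below it by a number 22 percentage points higher from compound 2 to compound 3 (beyond the scatter), a modest but real step that came with 1-methyl-1H-imidazol-2-yl in place of ethoxy on a saturated chain carbon bound to an aromatic carbon and a saturated chain carbon.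

Compound 4, `O=C(O)CC(c1ccc(F)cc1)c1ccc(OCC2COc3ccc(Cl)cc3O2)cc1`, is not yet measured. It differs from compound 3 thus: 4-fluorophenyl in place of 1-methyl-1H-imidazol-2-yl on a saturated chain carbon bound to an aromatic carbon and a saturated chain carbon. For the measured compounds named here, no measured pair swaps one aromatic group for another at that saturated chain carbon, so the only step that touches the position, from compound 2 to compound 3, tells merely that the substituent there can move the maximal response by a modest amount in either direction. Compound 4 is therefore expected near compound 3, with a number 3 percentage points lower from compound 3 to compound 4 (within the scatter) as the estimated step. Compound 4 is estimated at 65%, with a range from 45% to 85%.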

Compound 4, largest response reached (Emax), in percent of the reference or control that the assay uses: 83%
Beside the measured number, compound 4's estimate is 18 percentage points below it, within the range that was stated.
By their numbers in this assay, from the lowest: compound 2; then compound 3; then compounds 1 and 4 (each within the scatter of the next).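

In this assay, this saturated chain carbon now gives a comparison of two aromatic groups: 4-fluorophenyl in place of 1-methyl-1H-imidazol-2-yl gives a number 15 percentage points higher from compound 3 to compound 4 (beyond the scatter) and shows that the maximal response depends on which aromatic ring is carried there, not only on replacing ethoxy. Measured against ethoxy, 4-fluorophenyl gives a number 37 percentage points higher from compound 2 to compound 4 (beyond the scatter) and extends the smaller rise seen with 1-methyl-1H-imidazol-2-yl, so both aromatic groups stand above ethoxy among these three compounds. Nothing available here accounts for the difference between these groups.

The compounds shown do not separate the contribution of the fluorine from that of the six-membered carbon ring, which unsubstituted phenyl or 4-chlorophenyl at this carbon would address. As far as these compounds go, whether a non-aromatic group such as cyclohexyl or dimethylamino can match 4-fluorophenyl also remains open.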